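Trimethoxyphenyl in Place of Phenyl on a Shared Core

This account rests on a few compounds, and the source may have more. Where it says the series, first, only, none or still open, it means among the compounds named here.

Compound 1, `O=C(/C=C\Nc1ccc(C(F)(F)F)cc1)c1cn(-c2ccccc2)nc1-c1ccccc1`: > 50000 nM (a limit)
Compound 2, `COc1cc(N/C=C\C(=O)c2cn(-c3ccccc3)nc2-c2ccccc2)cc(OC)c1OC`: 5930 nM
Compound 3, `COc1ccc(-c2nn(-c3ccccc3)cc2C(=O)/C=C\Nc2ccc(F)cc2)cc1`: 5730 nM

Of the compounds shown here, three have been measured in a functional assay on PC-3 cells (Homo sapiens) for antiproliferative activity, read by MTT assay, with a stated time of 48 h; a lower number here means a stronger inhibitor, a higher number a weaker inhibitor. Compound 1 gives only a limit of the assay, > 50000 nM (the limit of > 50000 nM in this assay, at which 1 of the 3 values shown sits). Compound 2 gives 5930 nM. Compound 3 gives 5730 nM, and the gap between compound 2 and compound 3 lies within the scatter, so neither can be called the stronger of the two. Compound 2 therefore stands among the measured numbers rather than at the limit, and it is the starting point of the step followed here.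

Compound 4, `COc1cc(N/C=C\C(=O)c2cn(-c3ccccc3)nc2-c2cc(OC)c(OC)c(OC)c2)cc(OC)c1OC`, differs from compound 2 in one place: 3,4,5-trimethoxyphenyl in place of phenyl on an aromatic carbon. Going by the values given here, no pair of measured compounds differs in only this way, so the size of this step cannot be read from the data; the remaining compounds show other changes elsewhere on the shared core. The step is expected to be a modest lowering of the number, a 2.0-fold lower number from compound 2 to compound 4 (0.30 log units; within the scatter), though a step within the scatter is also plausible. Compound 4 is estimated at 3000 nM, with a range from 700 nM to 13000 nM.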

Compound 4, half-maximal inhibitory concentration: 14100 nM
Beside the measured number, compound 4's estimate is 4.7-fold (0.67 log units) below it; measured number above the stated range.
By their numbers in this assay, from the lowest: compounds 3 and 2 (each within the scatter of the next); then compound 4. At a limit, above all of these: compound 1.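

Putting 3,4,5-trimethoxyphenyl in place of phenyl on this aromatic carbon gives, in this assay, a 2.4-fold higher number from compound 2 to compound 4 (0.38 log units; beyond the scatter), so the number moves towards a weaker inhibitor, not a stronger one. This shows that the position is not indifferent to its group and that a larger group here, with 12 heavy atoms in place of 6, need not lower the number, though one step sets no general rule. Nothing measured here explains why the number rises.

The compounds shown leave open what a small group on this carbon, such as a methyl group, an amine or a carboxylic acid, would do. They also leave open whether the same change would give a step of similar size on the core of compound 1.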